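Swapping the basic ring on a diaryl urea series

The source may report more compounds than this note shows. Statements on the series, on what has been measured and on what is new or still open speak of the compounds shown alone.

Measured compounds:
compound 1 `CNC(=O)c1cc(Oc2ccc3nc(NC(=O)Nc4cc(C(F)(F)F)cc(C(F)(F)F)c4)sc3c2)ccn1` with 88.1%
compound 2 `CNC(=O)c1cc(Oc2ccc3nc(NC(=O)Nc4ccc(N5CCN(C)CC5)cc4)sc3c2)ccn1` with 30.5%

In a functional assay on SK-BR-3 cells (Homo sapiens) for inhibition, read by MTT assay, with a stated time of 2 days, tested at 10 uM (on this read-out lower numbers stand for less inhibition of growth and higher numbers for more inhibition of growth at the one concentration tested), compound 2 gives 30.5%, the lowest of the two numbers, while compound 1 gives 88.1%, a number far higher and well beyond the usual scatter. No single-point step between the two measured compounds is shown, so only their two values speak.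

Compound 3 `CNC(=O)c1cc(Oc2ccc3nc(NC(=O)Nc4ccc(C5CCN(C(C)C)CC5)cc4)sc3c2)ccn1` has not been measured in this assay. It differs from compound 2 in one place: 1-isopropylpiperidin-4-yl in place of 4-methylpiperazin-1-yl on an aromatic carbon. The two measured compounds give no direct guide to this change, since the other aryl substituent is different in kind in compound 1. The author expects a modest rise from compound 2 to compound 3 of a number 11.5 percentage points higher from compound 2 to compound 3 (beyond the scatter), possibly within the scatter. Compound 3 is therefore estimated at 42%, with a range from 18% to 70%.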

Compound 3, percent growth inhibition at one concentration: 45%
Beside the measured number, compound 3's estimate is 3 percentage points below it; measured number inside the range.
By their numbers in this assay, from the lowest: compound 2; then compound 3; then compound 1.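

In this assay, putting 1-isopropylpiperidin-4-yl in place of 4-methylpiperazin-1-yl on an aromatic carbon, para to a large group, gives a number 14.5 percentage points higher from compound 2 to compound 3 (beyond the scatter), a modest step but one beyond the scatter. This single comparison shows that growth inhibition at the one concentration tested does respond to a change of this ring at this position, and that the piperazine ring is not needed for the activity seen. No available measurement accounts for the step.

As far as these compounds go, the change alters the ring's hetero atoms, its point of attachment and the group on its nitrogen all at once, so it remains open which of these matters. A 1-methylpiperidin-4-yl group or a morpholine ring at the same place would help to separate these contributions.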